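A few compounds are considered here, and "the series" means these few. Any claim that something is new, unique, unknown or untested is made for them only; others in the source may bear on it.

Measured compounds:
Compound 1 `CC(C)c1ccccc1N1CCC(C(=O)Nc2ccc3c(c2)NC(=O)CO3)CC1` gives 180 nM in a functional assay for antagonist activity at transient receptor potential cation channel subfamily V member 1 (Homo sapiens), read by FLIPR and calcium flux; a lower number here means a stronger inhibitor, a higher number a weaker inhibitor.
Compound 2 `COC(=O)CC1Oc2ccc(NC(=O)C3CCN(c4cc(F)cc(F)c4)CC3)cc2NC1=O` gives 890 nM in this assay.

Of the two numbers, compound 1 has the lower one; compound 2 sits a good deal higher, a gap beyond the usual scatter. Compound 3 `O=C1COc2ccc(NC(=O)C3CCN(c4ccccc4Cl)CC3)cc2N1` is not yet measured. It differs from compound 1 in one place: chloro in place of isopropyl on an aromatic carbon. Within the data shown here, no measured pair shows this change, so the step can only be estimated. The expectation is a modest loss, with the number for compound 3 expected somewhat above that of compound 1, a step of a 1.8-fold higher number from compound 1 to compound 3 (0.25 log units; within the scatter). Compound 3 is therefore estimated at 320 nM, with a range from 100 nM to 1000 nM.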

Compound 3, half-maximal inhibitory concentration: 220 nM
Compound 3: the middle estimate sits 1.5-fold (0.16 log units) above what was measured; the measured number falls inside the stated range.
By their numbers in this assay, from the lowest: compounds 1 and 3 (each within the scatter of the next); then compound 2.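

Chloro in place of isopropyl on this aromatic carbon, ortho to a large group, gives a 1.2-fold higher number from compound 1 to compound 3 (0.09 log units; within the scatter) in this assay. At this position, one chlorine atom can therefore stand in for the three carbons of isopropyl with no change that this read-out can resolve. Nothing available explains why the two groups match.

On these data alone, whether other groups fit here, such as methoxy, nitrile or an amine, remains open. Compound 2 differs from compound 1 and compound 3 in more than one place, so it says nothing about this position.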